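Alkyl amide variation: from compound 3 to compound 4

A few compounds are considered here, and "the series" means these few. Any claim that something is new, unique, unknown or untested is made for them only; others in the source may bear on it.

Three amides on a shared core have been measured in a functional assay on HEK293 cells for positive allosteric modulation of metabotropic glutamate receptor 5 (Rattus norvegicus), read by fluorescence and calcium flux; a lower number here means a smaller maximal response, a higher number a larger maximal response. Compound 1 `C[C@@H](NC(=O)c1ccc(C#Cc2cccc(F)c2)cn1)C(C)(C)C` gives 66%. Compound 2 `CC(C)[C@@H](C)NC(=O)c1ccc(C#Cc2cccc(F)c2)cn1` gives 69.3%. Compound 3 `CC(C)CNC(=O)c1ccc(C#Cc2cccc(F)c2)cn1` gives 58.2%, the lowest of the three numbers; its gap to compound 1 lies within the scatter, its gap to compound 2 beyond it. The measured steps are a number 3.3 percentage points higher from compound 1 to compound 2 (within the scatter), a number 7.8 percentage points lower from compound 1 to compound 3 (within the scatter) and a number 11.1 percentage points lower from compound 2 to compound 3 (beyond the scatter).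

Compound 4 `CC(C)(C)CNC(=O)c1ccc(C#Cc2cccc(F)c2)cn1` differs from compound 3 by methyl in place of hydrogen on a saturated chain carbon bound to three saturated chain carbons. The step from compound 1 to compound 2 is the same kind of change at the same kind of place, run in the reverse direction, and it stayed within the scatter. The step from compound 2 to compound 3 concerns a different place and does not bear directly on this change. No step beyond the scatter is therefore expected in this assay, with at most a slight downward drift. The expected value for compound 4 is 56%, in the range 46% to 68%, meaning an expected step of a number 2.2 percentage points lower from compound 3 to compound 4 (within the scatter).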

Compound 4, largest response reached (reported as efficacy), in percent of the reference or control that the assay uses: 63.9%
Compound 4: the middle estimate sits 7.9 percentage points below what was measured; low and high end bracket the measured number.
By their numbers in this assay, from the lowest: compounds 3, 4, 1 and 2 (each within the scatter of the next, the first and the last beyond it).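

In this assay, isobutyl to neopentyl gives a number 5.7 percentage points higher from compound 3 to compound 4 (within the scatter), so this change stays within the scatter in both directions and on both cores: the same change on two cores in this assay, a number 3.3 percentage points higher (within the scatter) from compound 1 to compound 2 and a number 5.7 percentage points lower (within the scatter) from compound 4 to compound 3, 9 percentage points apart, within the scatter of two such steps. Among the compounds shown here, removing the methyl on the saturated chain carbon bound to an amide-type nitrogen and a saturated chain carbon gives a number 2.1 percentage points lower from compound 1 to compound 4 (within the scatter), so the one step beyond the scatter at that place does not recur, and the two readings of the change cannot be told apart: the same change on two cores in this assay, a number 11.1 percentage points lower (beyond the scatter) from compound 2 to compound 3 and a number 2.1 percentage points lower (within the scatter) from compound 1 to compound 4, 9 percentage points apart, within the scatter of two such steps. Neopentyl in place of 1,2-dimethylpropyl gives a number 5.4 percentage points lower from compound 2 to compound 4 (within the scatter), so the neopentyl amide stays level with both amides carrying a methyl at that place.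

The compounds shown leave open how a longer chain or a hydroxyl group on the amide side chain would read in this assay. Going by these compounds, all of them share one core, so whether these small steps hold on another core also remains open.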